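The compounds below may be only part of what the source reports. "The series", "measured", "known", "first", "only" and "open" are said of these compounds alone.

Working notes on the shared core of compound 2 `Cc1cccc(NC(=O)/N=C2\CCCN2C)c1` and its close relatives. Among the compounds with values here, in a functional assay on the whole organism with Rattus norvegicus as the target, with a stated time of 5 days (a higher number here means that more compound is needed for the effect, a lower number that less compound is needed), compound 2 gives 25 mg/kg, the only plain number in the set. Compound 1 `CCc1cccc(CC)c1NC(=O)/N=C1\CCCN1C` returns only a limit of the assay, > 25 mg/kg. Compound 3 `COc1cccc(OC)c1NC(=O)/N=C1\CCCN1C` also stops at a limit of the assay, > 25 mg/kg. Within the data shown here, no step between two measured compounds is available here, so the position of compound 2 is described only against (the limit of > 25 mg/kg in this assay, at which 2 of the 3 values shown sit), with compound 2 as the single compound that yields a number in this assay.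

Compound 4 `CN1CCC/C1=N\C(=O)Nc1ccccc1` is not yet measured. Compound 4 differs from compound 2 by hydrogen in place of methyl on an aromatic carbon. Among the measured compounds shown here, with no measured step to lean on, the expected step from compound 2 to compound 4 is no change at the digits printed from compound 2 to compound 4 (within the scatter) in this assay, most likely none beyond the scatter or a move toward a higher dose, and a limit is a real possibility. Compound 4 is therefore expected to give about 25 mg/kg in this assay, in the range 10 mg/kg to 60 mg/kg.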

Compound 4, minimum effective dose: 15 mg/kg
Compound 4: middle estimate off by 1.7-fold (0.22 log units), on the high side; the range from low to high includes it.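

Hydrogen in place of methyl on an aromatic carbon, meta to a large group, gives a 1.7-fold lower number from compound 2 to compound 4 (0.22 log units; within the scatter) in this assay. Within the data shown here, this is the first step that can be read at this position, and it shows that in this assay the methyl is not required for a plain number: compound 4, with hydrogen there, still yields one. The other compounds shown remain at a limit of the assay, so the set now holds two plain numbers within the scatter of each other and this limit: the limit of > 25 mg/kg in this assay, at which 2 of the 4 values shown sit.

Steps to the compounds at the limit cannot be read, so the substituted compounds give no size for any effect. From the compounds shown here alone, how an amine, a carboxylic acid or a longer chain on this same aromatic carbon would read in this assay stays open.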